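Swapping Methoxy for Iodo on a Triazole Thiourea

The compounds below may be only part of what the source reports. "The series", "measured", "known", "first", "only" and "open" are said of these compounds alone.

Of the compounds shown here, three have been tested in an ADME assay on MT4 cells (Homo sapiens) for cytotoxicity, read by MTT assay, with a stated time of 96 h; on this read-out higher numbers stand for lower toxicity in this test and lower numbers for higher toxicity in this test. Compound 1 `S=C(Nc1ccc(Cl)c(Cl)c1)Nc1nc[nH]n1` gives 47000 nM. Compound 2 `Nc1ncnn1/C(S)=N/Cc1ccccc1` gives 7400 nM. Compound 3 `COc1ccc(NC(=S)Nc2nc[nH]n2)cc1` reaches only a limit of the assay, > 100000 nM, so compound 3 stands at the limit of > 100000 nM in this assay, at which 1 of the 3 values shown sits, rather than at a measured number. Compound 4 `S=C(Nc1ccc(I)cc1)Nc1nc[nH]n1` has not yet been tested; it carries an (iodo in place of methoxy on an aromatic carbon). Among the measured compounds shown here, no measured pair differs by a single change of this kind, so the size of the step can only be gauged from compound 1, which carries chloro groups on that ring and gives 47000 nM. The step is expected to be a drop in this assay, an at least 1.6-fold lower number from compound 3 to compound 4 (0.22 log units; that floor lies within the scatter), somewhat beyond the usual scatter. Compound 4 is estimated at 60000 nM, with a range from 25000 nM to 150000 nM.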

Compound 4, half-maximal cytotoxic concentration: 46000 nM
Estimate against measurement, compound 4: 1.3-fold (0.12 log units) above; the range from low to high includes it.
By their numbers in this assay, from the lowest: compound 2; then compounds 4 and 1 (each within the scatter of the next). At a limit, above all of these: compound 3.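

Among the compounds shown here, putting iodo in place of methoxy at this spot on the ring gives an at least 2.1-fold lower number from compound 3 to compound 4 (0.33 log units; beyond the scatter) in this assay, the first reading of a single change here. Since lower numbers mean higher toxicity in this test, the spot is not neutral to this swap. The step is only a floor, since compound 3 stands at a limit rather than a measured number: the limit of > 100000 nM in this assay, at which 1 of the 4 values shown sits.

From the compounds shown here alone, how an amine or a carboxylic acid would read at this spot stays open. One pair also cannot separate the gain of iodo from the loss of methoxy.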